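This account rests on a few compounds, and the source may have more. Where it says the series, first, only, none or still open, it means among the compounds named here.

Measured so far:
- compound 1, `COc1cccc(Nc2cc3[nH]c(-c4cccc(C(F)(F)F)c4)nc3cn2)n1`, gives 85000 nM in a physicochemical assay for solubility, using the shake flask method, measured as kinetic solubility, with a stated time of 20 h, at pH 2; a higher number here means a more soluble compound, a lower number a less soluble compound
- compound 2, `COc1cccnc1Nc1cc2[nH]c(-c3cccc(C(F)(F)F)c3)nc2cn1`, gives 116000 nM in this assay

On these two numbers compound 2 stands highest, with compound 1 nearest; the gap between them, a 1.4-fold higher number from compound 1 to compound 2 (0.14 log units; within the scatter), lies within the scatter, so the two compounds cannot be separated by this assay.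

Compound 3 is `FC(F)(F)c1cccc(-c2nc3cnc(Nc4cccnn4)cc3[nH]2)c1`. Its difference from compound 2 is pyridazin-3-yl in place of 3-methoxypyridin-2-yl on a nitrogen on an aromatic ring. For the measured compounds named here, the only measured step, a 1.4-fold higher number from compound 1 to compound 2 (0.14 log units; within the scatter), swaps one methoxypyridinyl group for another and did not move the number beyond the scatter; no measured step removes the methoxy group or introduces a pyridazine, so the change from compound 2 to compound 3 has no close precedent here. Going by the values given here, with only that within-scatter step to go on, the expected step in this assay from compound 2 to compound 3 is small, in no clear direction, and is estimated as a 1.0-fold higher number from compound 2 to compound 3 (0.01 log units; within the scatter). Compound 3 is therefore expected to give about 120000 nM, within a range from 45000 nM to 320000 nM.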

Compound 3, solubility: 161000 nM
Beside the measured number, compound 3's estimate is 1.3-fold (0.13 log units) below it, and the stated range covers the measured number.
By their numbers in this assay, from the lowest: compounds 1, 2 and 3 (each within the scatter of the next).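

At this place, on a nitrogen on an aromatic ring, a methoxypyridinyl group can give way to pyridazin-3-yl, a ring with 2 hetero atoms and no methoxy group, and this assay still cannot separate the compounds (a 1.4-fold higher number from compound 2 to compound 3 (0.14 log units; within the scatter)) and (a 1.9-fold higher number from compound 1 to compound 3 (0.28 log units; within the scatter)). The earlier step only exchanged one methoxypyridinyl group for another, whereas these two steps change the ring itself, and both still lie within the scatter. No measurement is available here to explain these numbers.

From the compounds shown here alone, what a non-aromatic group at this place, such as a simple amine or a chain ending in a carboxylic acid, would do to the number stays open. So does the effect of replacing the trifluoromethyl group elsewhere in the molecule with, for example, a nitrile.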